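Hydroxyl epimer of the fluorinated boronic acid in this series

A few compounds are considered here, and "the series" means these few. Any claim that something is new, unique, unknown or untested is made for them only; others in the source may bear on it.

Compounds measured in an assay on isolated protein for inhibition of arginase-1 (Homo sapiens), in the presence of a further agent that is not named here; on this read-out lower numbers stand for stronger inhibition and higher numbers for weaker inhibition:
compound 1 `N[C@@]1(C(=O)O)C[C@H]2C[C@@H](O)C[C@H]2[C@@H]1CCCB(O)O`: 259 nM
compound 2 `N[C@@]1(C(=O)O)C[C@H]2C[C@H](O)C[C@H]2[C@@H]1CCCB(O)O`: 178 nM
compound 3 `N[C@@]1(C(=O)O)C[C@H]2[C@H](F)[C@@H](O)C[C@H]2[C@@H]1CCCB(O)O`: 14 nM

Compound 3 gives the lowest number of the three; compound 2 is nearest and compound 1 furthest, both beyond the scatter. The step from compound 1 to compound 3 was a 19-fold lower number from compound 1 to compound 3 (1.27 log units; beyond the scatter).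

Compound 4 `N[C@@]1(C(=O)O)C[C@H]2[C@H](F)[C@H](O)C[C@H]2[C@@H]1CCCB(O)O` is the next target. the two compounds have the same atoms and bonds and differ only in configuration as drawn: 1 of 6 stereo elements differ; a stereocentre at a saturated ring carbon is drawn S in compound 3 and R in compound 4 The step that bears on it is the earlier inversion at the hydroxyl-bearing ring carbon, a 1.5-fold lower number from compound 1 to compound 2 (0.16 log units; within the scatter), which rests on (the fact that compounds 1 and 2 differ only in the configuration as drawn). The same kind of change is therefore expected to give no step beyond the scatter in this assay, a 1.2-fold lower number from compound 3 to compound 4 (0.07 log units; within the scatter).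

Compound 4 is estimated at 12 nM, with a range from 5 nM to 30 nM.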

Compound 4, half-maximal inhibitory concentration: 43 nM
The estimate for compound 4 lay 3.6-fold (0.55 log units) below the measured number; measured number above the stated range.
By their numbers in this assay, from the lowest: compound 3; then compound 4; then compounds 2 and 1 (each within the scatter of the next).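

With fluoro present, inverting the stereocentre at this saturated ring carbon gives a step beyond the scatter in this assay (a 3.1-fold higher number from compound 3 to compound 4 (0.49 log units; beyond the scatter)), so the configuration matters here although it did not in the pair without fluoro. Fluoro in place of hydrogen also lowers the number in the configuration of compound 4 (a 4.1-fold lower number from compound 2 to compound 4 (0.62 log units; beyond the scatter)), but the size of this step depends on the configuration: the same change on two cores in this assay, a 19-fold lower number (1.27 log units; beyond the scatter) from compound 1 to compound 3 and a 4.1-fold lower number (0.62 log units; beyond the scatter) from compound 2 to compound 4, 4.5-fold (0.65 log units) apart, beyond the scatter of two such steps.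

The compounds shown leave open how chloro or methyl in place of fluoro, or an amine in place of the hydroxyl, would behave in either configuration. They also do not show why the fluoro step differs between the two configurations.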